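The compounds below may be only part of what the source reports. "The series", "measured", "known", "first", "only" and "open" are said of these compounds alone.

Of the compounds shown here, three have been measured. Compound 1 `Cc1cccc(-n2nncc2CN2C(=O)C3(C(C#N)=C(N)Oc4c3c3nc5ccccc5nc3c3ccccc43)c3ccccc32)c1` was tested in a functional assay on HepG2 cells (Homo sapiens) for antiproliferative activity, read by MTT assay, with a stated time of 48 h; on this read-out higher numbers stand for weaker inhibition and lower numbers for stronger inhibition. In this assay compound 1 gives only the limit > 50000 nM and no number. Compound 2 `CCOc1ccc(-n2nncc2CN2C(=O)C3(C(C#N)=C(N)Oc4c3c3nc5ccccc5nc3c3ccccc43)c3ccccc32)cc1` carries 4-ethoxyphenyl in place of 3-methylphenyl on an aromatic nitrogen. In this assay compound 2 also stops at the limit > 50000 nM. The step that the two limits leave unreadable from compound 1 to compound 2 is therefore unreadable in either direction. Compound 3 `Cc1cccc(-n2nncc2CN2C(=O)C3(C(C#N)=C(N)Oc4c(N)cc5nc6ccccc6nc5c43)c3ccccc32)c1` stands no differently: in this assay compound 3 likewise reaches only the limit > 50000 nM. Among the measured compounds shown here, all three values sit at the limit of > 50000 nM in this assay, at which 3 of the 3 values shown sit, so no measured step in the set can be read at all.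

Compound 4 `CCOc1ccccc1-n1nncc1CN1C(=O)C2(C(C#N)=C(N)Oc3c(N)cc4nc5ccccc5nc4c32)c2ccccc21` arises from compound 3 by 2-ethoxyphenyl in place of 3-methylphenyl on an aromatic nitrogen. For the measured compounds named here, the one measured step that bears on this kind of change, a step that the two limits leave unreadable from compound 1 to compound 2, gives no size because both of its ends rest at the limit of > 50000 nM in this assay, at which 3 of the 3 values shown sit. Compound 4 is therefore expected to remain at the limit, with an estimate of 80000 nM and a range from 30000 nM to 300000 nM. The expected step that the limit leaves unreadable from compound 3 to compound 4 is none beyond the scatter.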

Compound 4, half-maximal inhibitory concentration: 30500 nM
Compound 4: the middle estimate sits 2.6-fold (0.42 log units) above what was measured, and the stated range covers the measured number.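

On the aromatic nitrogen of the five-membered ring, 2-ethoxyphenyl in place of 3-methylphenyl gives in this assay an at least 1.6-fold lower number from compound 3 to compound 4 (0.21 log units; that floor lies within the scatter). Among the compounds shown here, compound 4 is thus the first compound in the set to give a number rather than a limit, so a readable value is reached on the core of compound 3 through a change at this position alone, though the floor of the step stays within the scatter and the true size remains unknown. The other compounds give no number to set beside it: the limit of > 50000 nM in this assay, at which 3 of the 4 values shown sit.

From the compounds shown here alone, it remains open whether the readable value depends on the ethoxy chain, its oxygen or its place on the phenyl ring, which 2-methylphenyl and 2-methoxyphenyl at this position would help separate. Going by these compounds, it is also open whether 2-ethoxyphenyl has any readable effect on the core of compound 1.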